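The source may hold more compounds than are shown below. What is called first, only, known or untested is meant among the compounds shown, and "the series" means these compounds.

The measured compounds:

`C[C@@H]1CCCN1c1c(C#N)c2c(N)nc(Nc3ccn(C)n3)cc2n1C` — compound 1, 6 nM
`C[C@@H]1CCCN1c1[nH]c2ncnc(N)c2c1C#N` — compound 2, 4 nM
`C[C@@H]1CCCN1c1cc2c(N)ncnc2n1C` — compound 3, 164 nM

In an assay on isolated protein for binding affinity to Leucine-rich repeat serine/threonine-protein kinase 2 (Homo sapiens), read by TR-FRET and LanthaScreen, with a stated time of 2 h (a higher number here means a weaker inhibitor, a lower number a stronger inhibitor), compound 1 gives 6 nM. That is the second highest of the three numbers shown. Its nearest neighbour is compound 2, whose value of 4 nM lies within the scatter of repeated measurements, so the two cannot be placed in order. Compound 3 stands furthest away, and its value of 164 nM is higher by an amount beyond the scatter.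

The step taken here leads from compound 1 to compound 4, `Cc1cn(C)nc1Nc1cc2c(c(N)n1)c(C#N)c(N1CCC[C@H]1C)n2C`. The difference between them is methyl in place of hydrogen on an aromatic carbon. For the measured compounds named here, no measured pair differs in one place in this way, so nothing in the data shows how such a change moves the numbers in this assay.

Compound 4 is therefore expected to sit close to compound 1, with a step of a 1.3-fold higher number from compound 1 to compound 4 (0.12 log units; within the scatter) that need not go beyond the scatter in either direction. For compound 4 the estimated value in this assay is 8 nM, within a range from 3 nM to 25 nM.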

Compound 4, inhibition constant: 63 nM
Estimate against measurement, compound 4: 7.9-fold (0.90 log units) below; measured number above the stated range.
By their numbers in this assay, from the lowest: compounds 2 and 1 (each within the scatter of the next); then compound 4; then compound 3.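

In this assay the change from 1-methyl-1H-pyrazol-3-yl to 1,4-dimethyl-1H-pyrazol-3-yl gives an 11-fold higher number from compound 1 to compound 4 (1.02 log units; beyond the scatter) and so shows that a single added carbon is enough to weaken binding clearly. For the compounds shown here, this is the first measured sign that this aromatic carbon, next to the ring atom that bears a large group, is sensitive to substitution, and it shows that hydrogen there is preferred over methyl. Nothing at hand accounts for the size of this step.

The compounds shown leave open whether any group on this carbon would cost as much, or whether a smaller atom such as fluorine would be tolerated. As far as these compounds go, it also remains open how the number would move if ethyl replaced the methyl on the ring atom that bears a methyl group.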